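From 4-methylphenyl to thiophen-2-yl on the shared core

This account rests on a few compounds, and the source may have more. Where it says the series, first, only, none or still open, it means among the compounds named here.

- Compound 1 (`COC1=C(C)C(=O)/C(=C(O)/C=C/c2ccc(C)cc2)C(=O)C1(C)C`): 8.2 ug/mL
- Compound 2 (`COC1=C(C)C(=O)/C(=C(O)/C=C/c2c(C)cc(C)cc2C)C(=O)C1(C)C`): > 20 ug/mL (a limit)

Among the measured compounds shown here, in a functional assay on PC-3 cells (Homo sapiens) for cytotoxicity (on this read-out lower numbers stand for an effect already at smaller amounts and higher numbers for an effect only at larger amounts of compound), compound 1 gives the only true number so far (8.2 ug/mL). For compound 2 the result is a limit (> 20 ug/mL).

Compound 3 (`COC1=C(C)C(=O)/C(=C(O)/C=C/c2cccs2)C(=O)C1(C)C`) has thiophen-2-yl in place of 4-methylphenyl on a double-bonded chain carbon bound to a double-bonded chain carbon. For the measured compounds named here, no measured pair shows this change, so in this assay no step beyond the scatter is expected, in either direction. The expected change is small (a 1.2-fold higher number from compound 1 to compound 3 (0.09 log units; within the scatter)). Compound 3 is estimated at 10 ug/mL, with an expected range from 4 ug/mL to 20 ug/mL.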

Compound 3, concentration for half-maximal effect: 18.2 ug/mL
The estimate for compound 3 lay 1.8-fold (0.26 log units) below the measured number; low and high end bracket the measured number.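

In this assay this place on the chain now gives a first readable step: thiophen-2-yl in place of 4-methylphenyl produces a 2.2-fold higher number from compound 1 to compound 3 (0.35 log units; beyond the scatter) and so a modest loss of effect. The swap changes the ring size, brings in sulfur and removes the methyl group all at once, and these cannot be told apart here. Compound 2 remains a limit, so steps to it cannot be read: the limit of > 20 ug/mL in this assay, at which 1 of the 3 values shown sits.

Still open, from the compounds shown here alone, is whether a phenyl ring carrying an amine or a carboxylic acid in place of the methyl group would move the number, and in which direction.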